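Swapping Benzyloxy for Bromo in a Growth Inhibitor Series

A few compounds are considered here, and "the series" means these few. Any claim that something is new, unique, unknown or untested is made for them only; others in the source may bear on it.

Three relatives sharing one core have been measured in a functional assay on DU-145 cells (Homo sapiens) for inhibition, read by trypan blue exclusion, with a stated time of 96 h; on this read-out lower numbers stand for stronger inhibition of growth and higher numbers for weaker inhibition of growth. Compound 3 `Cc1ccc(CS/C(=C/c2ccccc2OCc2ccccc2)C(=O)c2ccc(Cl)cc2)cc1` gives 1000 nM, the lowest number of the three. Compound 1 `Cc1ccc(CS/C(=C/c2ccc(Br)cc2)C(=O)c2ccc(Cl)cc2)cc1` gives 10000 nM, and compound 2 `Cc1ccc(CS/C(=C/c2ccc(C)s2)C(=O)c2ccc(Cl)cc2)cc1` gives 50000 nM. Still unmeasured is compound 4 `Cc1ccc(CS/C(=C/c2ccccc2Br)C(=O)c2ccc(Cl)cc2)cc1`, and the change that leads to it is bromo in place of benzyloxy on an aromatic carbon.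

Among the measured compounds shown here, no measured step makes this exact swap. For the measured compounds named here, the only single-place step so far replaces 4-bromophenyl with 5-methylthiophen-2-yl, a 5.0-fold higher number from compound 1 to compound 2 (0.70 log units; beyond the scatter). It is modest but beyond the scatter, so a change in this part of the molecule can move the number. The closer guide is a comparison of values. Compound 3 alone carries benzyloxy, and both compounds without it have higher numbers, including compound 1, which also bears a bromo group, at 10000 nM. A clear rise in this assay is therefore expected, meaning weaker inhibition of growth, although three compounds leave its size uncertain. The expected change is an 8.0-fold higher number from compound 3 to compound 4 (0.90 log units; beyond the scatter). For compound 4 the estimated value is 8000 nM, with an expected range from 2500 nM to 25000 nM.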

Compound 4, concentration for 50% growth inhibition: 10000 nM
The estimate for compound 4 lay 1.3-fold (0.10 log units) below the measured number, within the range that was stated.
By their numbers in this assay, from the lowest: compound 3; then compounds 1 and 4 (each within the scatter of the next); then compound 2.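

In this assay, among the compounds shown here, bromo in place of benzyloxy on this aromatic carbon, ortho to a large group, gives a 10-fold higher number from compound 3 to compound 4 (1.00 log units; beyond the scatter) as the first direct single-place comparison at this position, and here benzyloxy carries the lower number. The bromo group's place on the phenyl ring does not separate this pair, as 2-bromophenyl in place of 4-bromophenyl gives no change at the digits printed from compound 1 to compound 4 (within the scatter) and so leaves compound 3 apart from both bromo compounds. Among the compounds without benzyloxy, 2-bromophenyl in place of 5-methylthiophen-2-yl gives a 5.0-fold lower number from compound 2 to compound 4 (0.70 log units; beyond the scatter) and shows that the group on this chain carbon can still move the number when benzyloxy is absent.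

No measurement shown gives a reason for any of these steps. Still open, on these data alone, is whether the lower number of compound 3 needs the whole benzyloxy group or only part of it, a question that a methoxy or hydroxyl group on the same aromatic carbon would begin to answer, and whether a longer chain between the oxygen and the phenyl ring would lower the number further or raise it.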